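Diaryl ether ureas: replacing the chlorophenyl on the urea nitrogen

This account rests on a few compounds, and the source may have more. Where it says the series, first, only, none or still open, it means among the compounds named here.

Measured so far:
compound 1 `O=C(Nc1ccc(Cl)cc1)Nc1ccc(Oc2ccc(-c3nccs3)cc2)cc1` — 32.5%
compound 2 `O=C(Nc1ccc(Oc2ccc(-c3nccs3)cc2)cc1)Nc1cc(Br)cc(C(F)(F)F)c1` — 72.8%
compound 3 `O=C(Nc1ccc(Cl)cc1)Nc1ccc(Oc2ccc(-c3ncc[nH]3)cc2)cc1` — 47.6%

In a functional assay on MDA-MB-231 cells (Homo sapiens) for inhibition, read by MTT assay and WST assay, with a stated time of 72 h, tested at 10 uM (on this read-out lower numbers stand for less inhibition of growth and higher numbers for more inhibition of growth at the one concentration tested), compound 3 stands second highest of the three numbers, above compound 1 and below compound 2, both gaps beyond the scatter. Compound 4 `CC(=O)Oc1sccc1NC(=O)Nc1ccc(Oc2ccc(-c3ncc[nH]3)cc2)cc1` differs from compound 3 by 2-acetoxythiophen-3-yl in place of 4-chlorophenyl on an amide-type nitrogen. Within the data shown here, the only measured step at this nitrogen, a number 40.3 percentage points higher from compound 1 to compound 2 (beyond the scatter), shows that the group on the amide-type nitrogen can move the number a long way, but that step exchanged one six-membered carbon ring for another, whereas here a five-membered ring carrying an acetoxy group enters, so its direction is not settled by the data. A step of uncertain direction, a number 0.4 percentage points higher from compound 3 to compound 4 (within the scatter), is therefore expected. For compound 4 the estimate is 48%, within 22% to 74%.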

Compound 4, percent growth inhibition at one concentration: -1.46%
For compound 4 the middle estimate is 49.5 percentage points above the measured one, outside the stated range (below it).
By their numbers in this assay, from the lowest: compound 4; then compound 1; then compound 3; then compound 2.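

In this assay, among these compounds, the step of a number 49.1 percentage points lower from compound 3 to compound 4 (beyond the scatter) shows that a change on the amide-type nitrogen can also lower the number by a large margin, whereas the only earlier step there, a number 40.3 percentage points higher from compound 1 to compound 2 (beyond the scatter), raised it. The direction of change at this nitrogen therefore depends on the group that enters. No available evidence bears on the reason for this drop.

The compounds shown leave open whether the five-membered ring or its acetoxy group accounts for the drop. Also open, as far as these compounds go, is how a hydroxyl or a methyl in place of that acetoxy group would read.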